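The compounds below may be only part of what the source reports. "The series", "measured", "known", "first", "only" and "open" are said of these compounds alone.

Measured compounds:
- compound 1, `CC(C)OC(=O)N1CCC(O[C@H]2CC[C@H](Oc3cnc(S(C)(=O)=O)cn3)CC2)CC1`: 119 nM
- compound 2, `C[C@@H](CF)OC(=O)N1CCC(O[C@H]2CC[C@H](Oc3cnc(S(C)(=O)=O)cn3)CC2)CC1`: 356 nM
- compound 3, `CS(=O)(=O)c1cnc(O[C@H]2CC[C@H](OC3CCN(C(=O)OC4CCOC4)CC3)CC2)cn1`: 1500 nM

All three share one core and differ only in the group attached through an oxygen to the carbonyl carbon. In a functional assay on isolated protein for agonist activity at Glucose-dependent insulinotropic receptor (Rattus norvegicus), read by HTRF and cAMP accumulation (a higher number here means that more compound is needed for the effect, a lower number that less compound is needed), compound 1 gives 119 nM, compound 2 gives 356 nM and compound 3 gives 1500 nM. Compound 3 therefore stands at the highest number of the three, needing the most material; the steps of a 13-fold higher number from compound 1 to compound 3 (1.10 log units; beyond the scatter) and a 4.2-fold higher number from compound 2 to compound 3 (0.62 log units; beyond the scatter) are both beyond the scatter, as is a 3.0-fold higher number from compound 1 to compound 2 (0.48 log units; beyond the scatter).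

Compound 4, `CS(=O)(=O)c1cnc(O[C@H]2CC[C@H](OC3CCN(C(=O)C4(C(F)(F)F)CCCC4)CC3)CC2)cn1`, is not yet measured. It differs from compound 3 in a group of 9 heavy atoms (6 carbon, 3 fluorine; one five-membered non-aromatic ring of carbon only) in place of a group of 6 heavy atoms (4 carbon, 2 oxygen; one five-membered non-aromatic ring with 1 hetero atom), on a carbonyl carbon, at the position described as a carbonyl carbon whose other neighbours are an amide-type nitrogen in a ring. Going by the values given here, no measured step exchanges an oxygen-linked group for a carbon-linked one, so none bears directly on this change; the measured steps only show that what sits on this carbonyl carbon moves the number over a wide span, with the oxolan-3-yl group of compound 3 giving the highest value. Against that background the expectation is a lower number for compound 4 than for compound 3, with wide uncertainty: the estimated step is a 4.3-fold lower number from compound 3 to compound 4 (0.63 log units; beyond the scatter), and compound 4 is expected to give about 350 nM, somewhere between 60 nM and 2000 nM.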

Compound 4, half-maximal effective concentration: 108 nM
Estimate against measurement, compound 4: 3.2-fold (0.51 log units) above, within the range that was stated.
By their numbers in this assay, from the lowest: compounds 4 and 1 (each within the scatter of the next); then compound 2; then compound 3.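

This position does not need a group joined through oxygen: with a carbon-linked group on the carbonyl carbon, this assay shows a 14-fold lower number from compound 3 to compound 4 (1.14 log units; beyond the scatter) and a 3.3-fold lower number from compound 2 to compound 4 (0.52 log units; beyond the scatter), both beyond the scatter. The comparison with the isopropyl carbamate gives a 1.1-fold lower number from compound 1 to compound 4 (0.04 log units; within the scatter), which is within the scatter, so these two quite different groups cannot be told apart in this assay, even though one holds a carbon ring and fluorine and the other does not. Nothing available explains why this change moves the number as it does.

As far as these compounds go, because the ring and the fluorines enter together, their separate contributions remain open. A plain cyclopentyl group without fluorine would help separate them, while an amine or a carboxylic acid on this carbonyl carbon would test a different kind of group.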